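Swapping Fluorine for Chlorine on the Pendant Ring

The source may report more compounds than this note shows. Statements on the series, on what has been measured and on what is new or still open speak of the compounds shown alone.

In an assay on CHO cells for antagonist activity at transient receptor potential cation channel subfamily V member 1 (Homo sapiens), read by FLIPR (a lower number here means a stronger inhibitor, a higher number a weaker inhibitor), compound 2 `CC(C(=O)NCc1ccc(C(F)(F)F)cc1-c1cccc(F)c1)c1ccc(NS(C)(=O)=O)c(F)c1` gives 1.9 nM, the higher of the two numbers measured. Its neighbour compound 1 `CCCCN(C)c1cc(C(F)(F)F)ccc1CNC(=O)C(C)c1ccc(NS(C)(=O)=O)c(F)c1` gives 1.2 nM in this assay, and the step of a 1.6-fold higher number from compound 1 to compound 2 (0.20 log units; within the scatter) lies within the scatter, so the two cannot be ordered. Compound 3 `CC(C(=O)NCc1ccc(C(F)(F)F)cc1-c1cccc(Cl)c1)c1ccc(NS(C)(=O)=O)c(F)c1` differs from compound 2 only in chloro in place of fluoro on an aromatic carbon. Within the data shown here, no measured step bears on exchanging one halogen for another; the single known step exchanges a whole group. Compound 3 is therefore expected to give 2 nM in this assay, between 0.8 nM and 5 nM. The expected step is a 1.1-fold higher number from compound 2 to compound 3 (0.02 log units; within the scatter), none beyond the scatter.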

Compound 3, inhibition constant: 1 nM
Beside the measured number, compound 3's estimate is 2.0-fold (0.30 log units) above it; measured number inside the range.
By their numbers in this assay, from the lowest: compounds 3, 1 and 2 (each within the scatter of the next).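

In this assay, a change of chloro in place of fluoro on an aromatic carbon gives a 1.9-fold lower number from compound 2 to compound 3 (0.28 log units; within the scatter) so the two halogens cannot be told apart here. The 3-chlorophenyl group likewise cannot be separated from butyl(methyl)amino, with a 1.2-fold lower number from compound 1 to compound 3 (0.08 log units; within the scatter) so a second aryl group now matches the amine in this assay. Nothing available explains these numbers. From the compounds shown here alone, whether hydrogen, a methoxy group or a nitrile in place of the halogen would hold the number at this level stays open. So does the effect of a carboxylic acid or an amine at that place.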